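A few compounds are considered here, and "the series" means these few. Any claim that something is new, unique, unknown or untested is made for them only; others in the source may bear on it.

Of the compounds shown here, two built on one shared core have so far been measured in an assay on isolated protein for binding affinity to adenosine receptor A1 (Bos taurus); on this read-out lower numbers stand for stronger inhibition and higher numbers for weaker inhibition. Compound 1 `CC(O)CNc1nc(-c2ccccc2)nc2c1nnn2Cc1ccccc1Cl` gives 32000000 nM in this assay, and compound 2 `CCCCCCNc1nc(-c2ccccc2)nc2c1nnn2Cc1ccccc1Cl` gives 31000000 nM. Among the compounds with values here, the one step between them, a 1.0-fold lower number from compound 1 to compound 2 (0.01 log units; within the scatter), swaps one chain for another on a saturated chain carbon bound to a nitrogen on an aromatic ring and leaves the reading essentially unchanged. Among the two numbers, compound 2 has the lowest, but the gap to compound 1 lies within the scatter, so neither can be called the stronger binder.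

Compound 3 `CCNc1nc(-c2ccccc2)nc2c1nnn2Cc1ccccc1Cl` differs from compound 2 by hydrogen in place of butyl on a saturated chain carbon, two bonds along the chain from a nitrogen on an aromatic ring. Within the data shown here, the only step recorded, a change of chain at this same position, was within the scatter, so shortening the chain is expected to move the reading no further than the scatter allows. For compound 3 the expected value in this assay is 31000000 nM, most likely between 10000000 nM and 100000000 nM. For compound 3 this amounts to an expected step of no change at the digits printed from compound 2 to compound 3 (within the scatter), nothing beyond the scatter.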

Compound 3, inhibition constant: 463000000 nM
Estimate against measurement, compound 3: 15-fold (1.17 log units) below; measured number above the stated range.
By their numbers in this assay, from the lowest: compounds 2 and 1 (each within the scatter of the next); then compound 3.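

In this assay, the chain at this position proves able to move the reading after all: going from hexylamino to ethylamino gives a 15-fold higher number from compound 2 to compound 3 (1.17 log units; beyond the scatter) and leaves compound 3 the weakest binder of the three. The comparison with the other chain points the same way, with a 14-fold higher number from compound 1 to compound 3 (1.16 log units; beyond the scatter) also beyond the scatter, so the longer chains of compound 1 and compound 2 read alike while the shorter ethyl chain of compound 3 stands apart. Nothing available explains this loss of binding.

The compounds shown leave open how the reading changes along the series of chain lengths, since a butyl chain or a chain longer than hexyl could show where it turns. They also leave open whether an amine at the end of the chain would read like the hydroxyl-bearing chain of compound 1.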